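This account rests on a few compounds, and the source may have more. Where it says the series, first, only, none or still open, it means among the compounds named here.

Three compounds have been measured in a functional assay on SK-OV-3 cells (Homo sapiens) for inhibition, read by CCK-8 assay, with a stated time of 70 h; a higher number here means a weaker inhibitor, a lower number a stronger inhibitor:

Compound 1 `COc1ccc(OCCOCCNC2CCCC2)cc1`: 99100 nM
Compound 2 `c1ccc(COc2ccc(OCCOCCNC3CCCC3)cc2)cc1`: 24800 nM
Compound 3 `Clc1ccc(COc2ccc(OCCOCCNC3CCCC3)cc2)cc1`: 7670 nM

Among these three, compound 2, at 24800 nM, holds the middle place, with the second highest number. Compound 4 `c1ccc(COc2ccc(OCCOCCNC3CCCCC3)cc2)cc1` is still to be measured and departs from compound 2 in a single place: cyclohexyl in place of cyclopentyl on an amine nitrogen. In short, cyclohexyl stands in place of cyclopentyl on an amine nitrogen.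

Among the measured compounds shown here, none of the measured steps makes this change or touches the amine nitrogen. The series shows a 4.0-fold lower number from compound 1 to compound 2 (0.60 log units; beyond the scatter), which is modest, and a 3.2-fold lower number from compound 2 to compound 3 (0.51 log units; beyond the scatter), also modest. The largest is a 13-fold lower number from compound 1 to compound 3 (1.11 log units; beyond the scatter). All three steps come from changes on the aromatic side of the molecule, so they show that the number can move but give no direct measure of what a change in the ring on the amine nitrogen will do. With cyclopentyl as the only such ring tested so far, and with cyclohexyl a close relative of it, only a small shift is expected, with a slight lean towards a lower number and no firm basis for the direction. The expected move is a 1.2-fold lower number from compound 2 to compound 4 (0.09 log units; within the scatter), which would not stand beyond the scatter. Compound 4 is estimated at 20000 nM, with an expected range of 8000 nM to 50000 nM.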

Compound 4, half-maximal inhibitory concentration: 7370 nM
Estimate against measurement, compound 4: 2.7-fold (0.43 log units) above; the measured number lies below the stated range.
By their numbers in this assay, from the lowest: compounds 4 and 3 (each within the scatter of the next); then compound 2; then compound 1.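

In this assay, the ring on the amine nitrogen proves to be a place where the number responds: the step of a 3.4-fold lower number from compound 2 to compound 4 (0.53 log units; beyond the scatter) shows that the earlier movement was not confined to the aromatic side of the molecule. This step is graded modest, as is the aromatic step of a 3.2-fold lower number from compound 2 to compound 3 (0.51 log units; beyond the scatter), so a change from a cyclopentyl ring of 5 heavy atoms to a cyclohexyl ring of 6 heavy atoms, with no hydrogen-bond donors or acceptors on either group, can count for as much here as adding a chloro group to the aromatic ring. Nothing available explains why the cyclohexyl compound gives the lower number.

The compounds shown leave open whether the trend continues to a larger ring such as cycloheptyl, or whether an open chain such as tert-butyl or a ring containing oxygen such as tetrahydropyranyl would serve on the amine nitrogen as well as cyclohexyl. They also leave open whether cyclohexyl on the amine nitrogen and the 4-chlorophenyl group would add together in a single molecule.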